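Swapping fluorophenyl for pyridinyl on the ring nitrogen

The source may hold more compounds than are shown below. What is called first, only, known or untested is meant among the compounds shown, and "the series" means these compounds.

Measured so far:
compound 1 `O=C(O)c1cccc(-c2ccc(/C=C3\S/C(=N\c4ccc(F)cc4)N(c4ccc(F)cc4)C3=O)o2)c1`, giving > 200000 nM
compound 2 `O=C(O)c1cccc(-c2ccc(/C=C3\S/C(=N\c4ccccc4)N(c4ccc(F)cc4)C3=O)o2)c1`, giving > 200000 nM

Both compounds were tested in an ADME assay on Vero cells (Chlorocebus sabaeus) for cytotoxicity; a lower number here means that less compound is tolerated, a higher number that more compound is tolerated. For compound 1 the value > 200000 nM is a limit of the assay, not a measured number. For compound 2 the value > 200000 nM is likewise a limit. The step from compound 1 to compound 2 is a step that the two limits leave unreadable from compound 1 to compound 2, so its size cannot be read; what is known is the limit of > 200000 nM in this assay, at which 2 of the 2 values shown sit.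

Compound 3 `O=C(O)c1cccc(-c2ccc(/C=C3\S/C(=N\c4ccc(F)cc4)N(c4ccccn4)C3=O)o2)c1` differs from compound 1 by pyridin-2-yl in place of 4-fluorophenyl on an amide-type nitrogen in a ring. Within the data shown here, only one measured step touches this position, and it leaves its size unreadable, so no change beyond the scatter can be foreseen in this assay. The step from compound 1 to compound 3 is estimated as a step that the limit leaves unreadable from compound 1 to compound 3. Compound 3 is therefore expected to give about 300000 nM in this assay, within a range from 150000 nM to 1000000 nM, most likely again reported only as a limit.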

Compound 3, half-maximal cytotoxic concentration: > 200000 nM
Compound 3: no number, only a limit; the forecaster's own chance of this, stated with the estimate: 85%; the middle value lies beyond the limit too.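

For compound 3 the value > 200000 nM is a limit, not a number, so no size can be read for the change from compound 1 to compound 3. Left open is what actual number any of these compounds would give in this assay, and whether the changes shown alter it at all, as all three share one ceiling: the limit of > 200000 nM in this assay, at which 3 of the 3 values shown sit.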